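Benzyl in Place of Cyclopropylmethyl on the Shared Core

The source may hold more compounds than are shown below. What is called first, only, known or untested is meant among the compounds shown, and "the series" means these compounds.

Measured compounds:
Compound 1, `CCCC[C@@H]1O[C@H](COCc2ccccc2)[C@@H](OCc2ccccc2)[C@H](OCc2ccccc2)[C@H]1O`, in a functional assay on HOS cells (Homo sapiens) for antiproliferative activity, read by sulforhodamine B assay (on this read-out lower numbers stand for stronger inhibition of growth and higher numbers for weaker inhibition of growth), gives 40100 nM.
Compound 2, `O[C@@H]1[C@@H](OCc2ccccc2)[C@H](OCc2ccccc2)[C@@H](COCc2ccccc2)O[C@H]1CC1CC1`, in this assay reaches only a limit of the assay, > 50000 nM.

For the measured compounds named here, compound 2 thus has no exact number, only a limit, as the limit of > 50000 nM in this assay, at which 1 of the 2 values shown sits, records; the one measured step, an at least 1.2-fold higher number from compound 1 to compound 2 (0.09 log units; that floor lies within the scatter), links it to compound 1 and is too small to count as a real change. Compound 3, `O[C@@H]1[C@@H](OCc2ccccc2)[C@H](OCc2ccccc2)[C@@H](COCc2ccccc2)O[C@H]1Cc1ccccc1`, differs from compound 2 by phenyl in place of cyclopropyl on a saturated chain carbon bound to a saturated ring carbon. Going by the values given here, the only measured step that touches this position stays within the scatter, so nothing in the data suggests that exchanging the group here moves the number far. The expected step is an at least 1.1-fold lower number from compound 2 to compound 3 (0.04 log units; that floor lies within the scatter), within the scatter. The estimate for compound 3 is 45000 nM, with a range from 15000 nM to 150000 nM, and a fair chance that again only a limit is reported.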

Compound 3, concentration for 50% growth inhibition: 29200 nM
Estimate against measurement, compound 3: 1.5-fold (0.19 log units) above, within the range that was stated.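

With compound 3, a ring group at this position has an exact number in this assay, whereas the reading for compound 2 is only a limit of the assay: the limit of > 50000 nM in this assay, at which 1 of the 3 values shown sits. Phenyl in place of cyclopropyl gives an at least 1.7-fold lower number from compound 2 to compound 3 (0.23 log units; that floor lies within the scatter) and so sets only a floor on this step, leaving its true size unknown. Phenyl in place of propyl gives a 1.4-fold lower number from compound 1 to compound 3 (0.14 log units; within the scatter) and so shows that, on these values, the aromatic ring and the open chain cannot be told apart at this position.

The compounds shown leave open whether any group here can move the number beyond the scatter. All the groups compared at this position are built of carbon only, so an amine or a carboxylic acid on this chain carbon remains an untested kind of change.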